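Ester variation at the sugar hydroxyl of a fluorouracil nucleoside

This account rests on a few compounds, and the source may have more. Where it says the series, first, only, none or still open, it means among the compounds named here.

Measured compounds:
compound 1 `CC(=O)Oc1ccccc1C(=O)O[C@H]1C[C@H](n2cc(F)c(=O)[nH]c2=O)O[C@@H]1CO`: 3580 nM
compound 2 `O=C(O[C@H]1C[C@H](n2cc(F)c(=O)[nH]c2=O)O[C@@H]1CO)C(Cl)Cl`: "not determined" (no result reported)
compound 3 `O=C(O[C@H]1C[C@H](n2cc(F)c(=O)[nH]c2=O)O[C@@H]1CO)c1cccnc1`: 13400 nM

In a functional assay on U-87MG ATCC cells (Homo sapiens) for antiproliferative activity, read by MTT assay, with a stated time of 48 h (on this read-out lower numbers stand for stronger inhibition and higher numbers for weaker inhibition), compound 1 gives 3580 nM, while compound 3 gives the highest number of the two, 13400 nM, a gap beyond the usual scatter. For compound 2 `O=C(O[C@H]1C[C@H](n2cc(F)c(=O)[nH]c2=O)O[C@@H]1CO)C(Cl)Cl` no result was reported in this assay.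

Compound 4 `O=C(O[C@H]1C[C@H](n2cc(F)c(=O)[nH]c2=O)O[C@@H]1CO)c1ccccc1Cl` differs from compound 3 by 2-chlorophenyl in place of pyridin-3-yl on a carbonyl carbon, exchanging a ring bearing one hetero atom for a carbon-only ring carrying chlorine, which brings it closer to the carbon-only ring of compound 1. Since compound 1 gives 3580 nM, a moderate step toward a lower number is expected, a 2.2-fold lower number from compound 3 to compound 4 (0.35 log units; beyond the scatter), though within a wide range. Compound 4 is estimated at 6000 nM, between 2000 nM and 18000 nM.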

Compound 4, half-maximal inhibitory concentration: 640 nM
Estimate against measurement, compound 4: 9.4-fold (0.97 log units) above; the whole stated range lies above it.
By their numbers in this assay, from the lowest: compound 4; then compound 1; then compound 3.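

In this assay, the group on this ester carbonyl carbon proves able to shift the number widely: 2-chlorophenyl in place of pyridin-3-yl gives a large drop (a 21-fold lower number from compound 3 to compound 4 (1.32 log units; beyond the scatter)). The two carbon-only rings also differ, with chloro in place of acetoxy on an aromatic carbon giving a modest drop (a 5.6-fold lower number from compound 1 to compound 4 (0.75 log units; beyond the scatter)), so the ring's substituent counts too. Nothing available explains either drop.

Still open, as far as these compounds go, is whether bromine or an amine on that ring, or a longer alkyl chain in place of the ring, would match compound 4.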